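Aryl substituent swap in the octadecyl amide series

The source may hold more compounds than are shown below. What is called first, only, known or untested is meant among the compounds shown, and "the series" means these compounds.

Measured so far:
compound 1, `CCCCCCCCCCCCCCCCCCNC(=O)[C@@H]1CSC(c2ccc(OC)cc2)N1`: 1500 nM
compound 2, `CCCCCCCCCCCCCCCCCCNC(=O)[C@@H]1CSC(c2ccc(N(C)C)cc2)N1`: 1100 nM

Both numbers come from a functional assay on PPC-1 cells (Homo sapiens) for antiproliferative activity, read by sulforhodamine B assay; a higher number here means a weaker inhibitor, a lower number a stronger inhibitor. Going by the values given here, compound 2 carries the lowest of the two numbers, yet the only step joining them, a 1.4-fold lower number from compound 1 to compound 2 (0.13 log units; within the scatter), lies within the scatter, and the two compounds cannot be separated on this assay.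

Compound 3, `CCCCCCCCCCCCCCCCCCNC(=O)[C@@H]1CSC(c2ccc(O)cc2)N1`, is not yet measured. Its change from compound 2 is hydroxy in place of dimethylamino on an aromatic carbon. Among the compounds with values here, one measured step bears on it, and only loosely: it too altered the group on that aromatic carbon, dimethylamino in place of methoxy, and it moved the number within the scatter only. No measurement shows what a hydroxy group on that carbon does. Within the data shown here, with a single step of that size as the only guide, there is no ground for expecting a move beyond the scatter in either direction; the working expectation is that compound 3 stays close to compound 2.

The estimate for compound 3 in this assay is 1300 nM, with a range of 600 nM to 2800 nM. The step this estimate implies is a 1.2-fold higher number from compound 2 to compound 3 (0.07 log units; within the scatter), expected to remain within the scatter.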

Compound 3, half-maximal inhibitory concentration: 820 nM
For compound 3 the middle estimate is 1.6-fold (0.20 log units) above the measured one; the measured number falls inside the stated range.
By their numbers in this assay, from the lowest: compounds 3, 2 and 1 (each within the scatter of the next).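

In this assay, hydroxy on this aromatic carbon, para to a large group, gives a 1.3-fold lower number from compound 2 to compound 3 (0.13 log units; within the scatter) when it replaces dimethylamino, and removing the methyl from the oxygen gives a 1.8-fold lower number from compound 1 to compound 3 (0.26 log units; within the scatter); neither step separates the compounds. Going by these compounds alone, the position therefore accepts a swap from 3 heavy atoms and 0 hydrogen-bond donors to 1 heavy atom and 1 hydrogen-bond donor without a move beyond the scatter, so the methoxy, dimethylamino and hydroxy compounds form one unresolved group, and the free hydroxy adds a third substituent to the single comparison available earlier. No supporting measurement is available to account for these small steps.

The compounds shown leave open whether a carboxylic acid, a primary amine or a fluorine atom on the same aromatic carbon would take the number outside the scatter of these three compounds. They also leave open whether the same insensitivity to the aryl substituent would hold with a shorter chain in place of the octadecyl group on the amide.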